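Moving a hydroxyl around the anilino ring of a quinazoline-type scaffold

This account rests on a few compounds, and the source may have more. Where it says the series, first, only, none or still open, it means among the compounds named here.

Of the compounds shown here, three with a shared core have been tested in a functional assay on MCF7 cells (Homo sapiens) for cytotoxicity, read by MTT assay, with a stated time of 48 h; a lower number here means a stronger inhibitor, a higher number a weaker inhibitor. Compound 1 `Fc1cccc(-c2nc(Nc3ccccc3Cl)c3cc(F)ccc3n2)c1` gives only a limit of the assay, > 50000 nM. Compound 2 `Fc1cccc(-c2nc(Nc3ccccc3Br)c3cc(F)ccc3n2)c1` likewise gives only a limit, > 50000 nM. Compound 3 `Oc1cccc(Nc2nc(-c3cccc(F)c3)nc3ccc(F)cc23)c1` also reaches no number, its value being the limit > 50000 nM. The three measured steps, a step that the two limits leave unreadable from compound 1 to compound 2, a step that the two limits leave unreadable from compound 1 to compound 3 and a step that the two limits leave unreadable from compound 2 to compound 3, are therefore all unreadable in size, as the limit of > 50000 nM in this assay, at which 3 of the 3 values shown sit, summarises.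

Compound 4 `Oc1ccccc1Nc1nc(-c2cccc(F)c2)nc2ccc(F)cc12` is the next candidate; it differs from compound 3 by 2-hydroxyphenyl in place of 3-hydroxyphenyl on a nitrogen on an aromatic ring. Going by the values given here, none of the measured steps gives a readable size, so nothing in this set points to a direction for this change; the closest analogue, compound 3, sits at the limit, and no step beyond the scatter is evident anywhere in this assay. Compound 4 is therefore expected to remain at or near the limit, with an estimate of 60000 nM in this assay, spanning 20000 nM to 200000 nM. The expected step is estimated as a step that the limit leaves unreadable from compound 3 to compound 4.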

Compound 4, half-maximal inhibitory concentration: > 50000 nM
Compound 4: a limit, no number; the forecaster's own chance of this, stated with the estimate: 80%; the middle value does not contradict the limit.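

In this assay compound 4 gives only a limit, > 50000 nM, so its steps from compound 1, compound 2 and compound 3 cannot be read. The compounds shown leave open whether the 2-hydroxyphenyl, 3-hydroxyphenyl, 2-chlorophenyl and 2-bromophenyl groups differ at all in this assay: the limit of > 50000 nM in this assay, at which 4 of the 4 values shown sit.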